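Amino in place of hydroxy on compound 2

The source may report more compounds than this note shows. Statements on the series, on what has been measured and on what is new or still open speak of the compounds shown alone.

compound 1 `COc1ccc(/C=C(/F)c2cc(OC)c(OC)c(OC)c2)cc1O` gives 1700 nM
compound 2 `COc1ccc(/C=C(\F)c2cc(OC)c(OC)c(OC)c2)cc1O` gives 13000 nM
compound 3 `COc1ccc(/C=C\c2cc(OC)c(OC)c(OC)c2)cc1[N+](=O)[O-]` gives 135000 nM

In a functional assay on cells (Endothelial cell, Bos taurus) for antiproliferative activity (a higher number here means a weaker inhibitor, a lower number a stronger inhibitor), compound 2 holds the second highest of these three numbers, with compound 1 lower at 1700 nM and compound 3 higher at 135000 nM. The next compound is compound 4 `COc1ccc(/C=C(\F)c2cc(OC)c(OC)c(OC)c2)cc1N`, which has amino in place of hydroxy on an aromatic carbon, ortho to a methoxy group, and the count of that change reads (amino in place of hydroxy on an aromatic carbon). Going by the values given here, no measured step covers this exchange. Among the compounds with values here, the only step available, a 7.6-fold higher number from compound 1 to compound 2 (0.88 log units; beyond the scatter), goes with the fact that compounds 1 and 2 differ only in the configuration as drawn, so it says nothing about amino and serves only as a yardstick for the size of one change. Compound 3 differs from compound 2 in more than one place and gives no direction. In this assay no shift beyond the scatter is therefore expected, and the estimated step is a 1.3-fold lower number from compound 2 to compound 4 (0.11 log units; within the scatter), with its direction uncertain. For compound 4 the estimated value is 10000 nM, with an expected range from 2000 nM to 50000 nM.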

Compound 4, half-maximal inhibitory concentration: 86000 nM
Estimate against measurement, compound 4: 8.6-fold (0.93 log units) below; the measured number lies above the stated range.
By their numbers in this assay, from the lowest: compound 1; then compound 2; then compounds 4 and 3 (each within the scatter of the next).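

In this assay, this position, ortho to a methoxy group, proves sensitive to the exchange: amino in place of hydroxy on an aromatic carbon gives a 6.6-fold higher number from compound 2 to compound 4 (0.82 log units; beyond the scatter) and so moves compound 4 well away from compound 2. Hydroxy and amino match in heavy atoms, hydrogen-bond donors, hydrogen-bond acceptors and net charge as counted, so those counts do not separate the two groups, although the measured numbers do. The only fact at hand concerns the configuration of compounds 1 and 2 and does not bear on this exchange, so nothing here accounts for the step.

Going by these compounds, whether the same exchange would give a similar step on compound 1 remains open. So does how a methylamino group, a fluorine or a methyl group would stand at this position.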